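A few compounds are considered here, and "the series" means these few. Any claim that something is new, unique, unknown or untested is made for them only; others in the source may bear on it.

Measured so far: compound 1 `O[C@@H]1[C@H](O)CN[C@@H]1CCn1cc(-c2ccccc2)nn1`, 89%; compound 2 `O[C@@H]1[C@@H](c2cn(Cc3ccccc3)nn2)NC[C@@H]1O`, "not active" (no number reported).

In an assay on isolated protein for inhibition of alpha-galactosidase (Coffea arabica), with stated times of 5 min and 20 min, tested at 1 mM (on this read-out lower numbers stand for less inhibition and higher numbers for more inhibition at the one concentration tested (going by the name of the read-out)), compound 1 gives 89%, whereas compound 2 is reported only as "not active" (no number reported), so no single number stands for compound 2 and it cannot be placed against compound 1 by a step. Compound 3 `O[C@@H]1[C@H](O)CN[C@@H]1c1cn(Cc2ccccc2)nn1` is the next entry. Relative to compound 2 the change is the two compounds have the same atoms and bonds and differ only in configuration as drawn: 2 of 3 stereo elements differ; a stereocentre at a saturated ring carbon is drawn R in compound 2 and S in compound 3; a stereocentre at a saturated ring carbon is drawn S in compound 2 and R in compound 3. For the measured compounds named here, no step between measured compounds is known here, so the size and direction of the move in this assay cannot be read from the data; a change of configuration alone may shift the read-out beyond the scatter either way. Compound 3 is expected to give an estimated 30%, within 0% to 80%.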

Compound 3, a percentage reported as inhibition, at one concentration (the size of the read-out at that concentration, not a potency): "not active" (no number reported)
Compound 3: no number reported; there is nothing to compare the estimate with.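

No new step can be read: compound 2 and compound 3 are both reported in this assay as "not active" with no number, so neither can be placed against the other. On these data alone, whether configuration changes the read-out in this pair remains open, as does how either compares with compound 1.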